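Lengthening the Side Chain of a Bisphenol Cytotoxin

The source may report more compounds than this note shows. Statements on the series, on what has been measured and on what is new or still open speak of the compounds shown alone.

Measured so far:
- compound 1, `COc1cc(C(c2ccc(O)c(OC)c2)[C@H](CC(C)C)C(C)C)ccc1O`: 9600 nM
- compound 2, `COc1cc(C(c2ccc(O)c(OC)c2)[C@H](C)[C@@H](C)CO)ccc1O`: > 100000 nM
- compound 3, `COC[C@H](C)[C@H](C)C(c1ccc(O)c(OC)c1)c1ccc(O)c(OC)c1`: 82000 nM

In a functional assay on HL-60 cells (Homo sapiens) for cytotoxicity, read by WST assay, with a stated time of 48 h (a lower number here means a stronger inhibitor, a higher number a weaker inhibitor), compound 1 gives 9600 nM, the lowest of the two numbers available. Compound 2 reaches only a limit of the assay, > 100000 nM. Compound 3 gives 82000 nM. Compound 1 therefore stands as the strongest of the measured set, with an 8.5-fold higher number from compound 1 to compound 3 (0.93 log units; beyond the scatter) and an at least 10-fold higher number from compound 1 to compound 2 (1.01 log units; beyond the scatter). Both of these steps replace the whole branched chain on the saturated carbon bound to two aromatic carbons with a shorter chain carrying an oxygen, so they weaken the compound but speak only indirectly to a change that keeps the branched chain and merely lengthens one arm.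

Compound 4, `CCCCCCCC[C@H](C(C)C)C(c1ccc(O)c(OC)c1)c1ccc(O)c(OC)c1`, differs from compound 1 as follows: heptyl in place of isopropyl on a saturated chain carbon, three bonds along the chain from two aromatic carbons. Among the compounds with values here, no measured pair shows a carbon-only lengthening of this kind, so the expected step is small: a 1.4-fold lower number from compound 1 to compound 4 (0.14 log units; within the scatter), within the usual scatter. Compound 4 is thus estimated at 7000 nM, with a range from 2500 nM to 20000 nM.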

Compound 4, half-maximal inhibitory concentration: 3700 nM
The estimate for compound 4 lay 1.9-fold (0.28 log units) above the measured number; low and high end bracket the measured number.
By their numbers in this assay, from the lowest: compound 4; then compound 1; then compound 3. At a limit, above all of these: compound 2.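

In this assay, heptyl in place of isopropyl gives a 2.6-fold lower number from compound 1 to compound 4 (0.41 log units; beyond the scatter). This is the first change shown at this position that adds only carbon, and it moves the number down, whereas the shorter oxygen-bearing chains of compound 2 and compound 3 came with higher numbers, so this part of the molecule accepts a much longer carbon chain without any loss in this cell assay. The data shown offer no explanation for why the longer chain gives the lower number.

From the compounds shown here alone, one step cannot establish a trend with chain length, so it remains open whether the number would keep falling with a chain longer than heptyl or would turn back up. Going by these compounds, it is also open how a heptyl chain carrying an amine or a carboxylic acid would behave.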